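Swapping bromo and fluoro at an assay limit

A few compounds are considered here, and "the series" means these few. Any claim that something is new, unique, unknown or untested is made for them only; others in the source may bear on it.

In an ADME assay on microsomes from liver (Canis lupus familiaris) for metabolic stability (on this read-out higher numbers stand for a longer-lived compound and lower numbers for a shorter-lived compound), compound 1 (`Nc1nc(NCCNc2ncc(-c3ncc[nH]3)c(-c3ccccc3Cl)n2)ccc1[N+](=O)[O-]`) gives > 0.5 h as a limit, not a number. Compound 2 (`Nc1nc(NCCNc2ncc(-c3ncc[nH]3)c(-c3ccc(F)cc3F)n2)ccc1[N+](=O)[O-]`) gives > 0.5 h as a limit too. Compound 3 (`Nc1nc(NCCNc2ncc(-c3ncc[nH]3)c(-c3ccc(F)cc3Br)n2)ccc1[N+](=O)[O-]`) likewise gives > 0.5 h as a limit, so it stands with the other two (the limit of > 0.5 h in this assay, at which 3 of the 3 values shown sit). Compound 4 (`Nc1nc(NCCNc2ncc(-c3ncc[nH]3)c(-c3ccc(Br)cc3F)n2)ccc1[N+](=O)[O-]`) carries 4-bromo-2-fluorophenyl in place of 2-bromo-4-fluorophenyl (4-bromo-2-fluorophenyl in place of 2-bromo-4-fluorophenyl on an aromatic carbon). Two measured changes bear on this swap, namely a step that the two limits leave unreadable from compound 2 to compound 3 and also a step that the two limits leave unreadable from compound 1 to compound 3 on the same group. Neither offers a size to carry over. In this assay the expected outcome is a step that the limit leaves unreadable from compound 3 to compound 4 with no direction favoured and nothing beyond the usual scatter. Compound 4 is estimated at 0.7 h with a range from 0.4 h to 1.5 h around that figure, and it may well be reported as a limit again.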

Compound 4, half-life: > 0.5 h
Compound 4: a limit, no number (the forecaster's own chance of this, stated with the estimate: 80%); the middle value does not contradict the limit.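

Compound 4 also gives only a limit, so no step from compound 1, compound 2 or compound 3 to compound 4 can be read: the limit of > 0.5 h in this assay, at which 4 of the 4 values shown sit.

As far as these compounds go, how long these four compounds actually last in this assay, and whether moving the bromo and fluoro groups matters, stays open.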